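Extending the chain: ethyl to propyl on the core

The source may hold more compounds than are shown below. What is called first, only, known or untested is meant among the compounds shown, and "the series" means these compounds.

Measured so far, in a physicochemical assay for lipophilicity, using the shake flask method, in phosphate buffer, measured as octanol-water partition, at pH 7.4; on this read-out higher numbers stand for higher lipophilicity and lower numbers for lower lipophilicity:
- compound 1 `CC[C@@H](c1ccc(C(=O)O)c(Oc2cccc(Cl)c2)c1F)N1CCC[C@H](n2cc(C)c(=O)[nH]c2=O)C1` gives 0.11
- compound 2 `CC[C@H](c1ccc(C(=O)O)c(Oc2cccc(Cl)c2)c1)N1CCC[C@H](n2cc(C)c(=O)[nH]c2=O)C1` gives 0.22
- compound 3 `CC[C@H](c1ccc(C(=O)O)c(Oc2cccc(Cl)c2)c1F)N1CCC[C@H](n2cc(C)c(=O)[nH]c2=O)C1` gives 0.12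

Compound 1 stands lowest of these three numbers, but only on paper: its nearest neighbour is compound 3, a number 0.01 log units higher from compound 1 to compound 3 (within the scatter), and even compound 2 lies within the usual scatter of it. Compound 1 and compound 3 share every atom and bond and differ only in the configuration as drawn (the fact that compounds 1 and 3 differ only in the configuration as drawn). Compound 2 and compound 3 differ by a fluoro on an aromatic carbon, a number 0.10 log units lower from compound 2 to compound 3 (within the scatter).

Compound 4 `CCC[C@@H](c1ccc(C(=O)O)c(Oc2cccc(Cl)c2)c1F)N1CCC[C@H](n2cc(C)c(=O)[nH]c2=O)C1` is not yet measured. It differs from compound 1 by methyl in place of hydrogen on a saturated chain carbon, three bonds along the chain from an amine nitrogen in a ring and an aromatic carbon. Within the data shown here, none of the measured steps involves a change of this kind, so no direct guide exists among them. The change itself is the addition of one carbon to the chain, from ethyl to propyl, and for compound 4 a small upward step, a number 0.34 log units higher from compound 1 to compound 4 (beyond the scatter), is expected in this assay. The estimate for compound 4 is 0.45, with a range from 0.1 to 0.8.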

Compound 4, distribution coefficient: 0.51
For compound 4 the middle estimate is 0.06 log units below the measured one; low and high end bracket the measured number.
By their numbers in this assay, from the lowest: compounds 1, 3, 2 and 4 (each within the scatter of the next, the first and the last beyond it).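

Going from ethyl to propyl is the first change among these compounds to give a step beyond the scatter in this assay: a number 0.40 log units higher from compound 1 to compound 4 (beyond the scatter). Among these compounds, the two earlier steps, one swapping the configuration at the saturated chain carbon and one placing fluoro on an aromatic carbon, both stayed within the scatter, so this saturated chain carbon is the first position here where a single change shifts the read-out measurably. Nothing on hand accounts for why one added carbon at this position gives a step of this size.

On these data alone, this step rests on a single pair of compounds, so it stays open whether the same change would give a similar step with the opposite configuration at the chain carbon, as in compound 3, or without the fluoro, as in compound 2. Also open, as far as these compounds go, is how this assay would respond to a longer chain such as butyl, to a branched chain such as isopropyl, or to a hydroxyl or an amine at the end of the chain.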